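Shortening the basic side chain of compound 1

This account rests on a few compounds, and the source may have more. Where it says the series, first, only, none or still open, it means among the compounds named here.

Compound 1, `C/C(=N/c1ccnc2cc(Cl)ccc12)NCCCCN1CCCCC1`, carries a chain that ends in a saturated ring with one nitrogen. In an ADME assay (liver) for metabolic stability, with Liver microsome (Homo sapiens) as the target, read by LC-MS, using microsomes, tested at 1 uM (a higher number here means that the compound lasts longer, a lower number that the compound disappears faster), compound 1 reaches the limit of the measurement, giving > 1 h, which is a limit rather than a number. Compound 3, `CCN(CC)CCCN(CCCN(CC)CC)/C(C)=N\c1ccnc2cc(Cl)ccc12`, also sits at that limit in this assay with > 1 h. Compound 2, `Clc1ccc2c(N(CCCN3CCCCC3)/C(=N/CCCN3CCCCC3)c3ccccc3)ccnc2c1`, gives 0.517 h in this assay, a measured number. Thus compound 1 stands at the ceiling of the numbers shown, and the evidence rests on (the limit of > 1 h in this assay, at which 2 of the 3 values shown sit).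

Compound 4, `CCN(CC)CCN/C(C)=N\c1ccnc2cc(Cl)ccc12`, has not yet been measured in this assay. It differs from compound 1 in one place: diethylamino in place of 2-(piperidin-1-yl)ethyl on a saturated chain carbon, two bonds along the chain from an amine nitrogen. For the measured compounds named here, no pair of measured compounds differing in exactly one place is available, so the size of this step cannot be read from a measured step; it can only be estimated. Since compound 3, whose chains also end in diethylamino groups, shows > 1 h, compound 4 is expected to stay near the limit rather than fall sharply.

The step from compound 1 to compound 4 is estimated as a step that the limit leaves unreadable from compound 1 to compound 4, within the scatter. Compound 4 is expected to give about 1.2 h, in a range from 0.5 h to 3 h.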

Compound 4, half-life: 0.433 h
The estimate for compound 4 lay 2.8-fold (0.44 log units) above the measured number, outside the stated range (below it).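

This is the first step among the compounds shown that can be read at this place, on a saturated chain carbon, two bonds along the chain from an amine nitrogen: in this assay, diethylamino in place of 2-(piperidin-1-yl)ethyl gives an at least 2.3-fold lower number from compound 1 to compound 4 (0.36 log units; beyond the scatter). The position is therefore not indifferent to this change, which removes the six-membered non-aromatic ring and brings the group from 8 heavy atoms to 5, with the hydrogen-bond donor and acceptor counts of the group unchanged. The full size of the step cannot be read, because compound 1 stands at a limit and not at a number: the limit of > 1 h in this assay, at which 2 of the 4 values shown sit.

The compounds shown do not separate the loss of the ring from the loss of heavy atoms, so either could go with the step. On these data alone, whether a morpholine or pyrrolidine ring at the end of the chain, or a dimethylamino group at this same place, would stay at the limit or fall to a measured number remains open.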